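Hydroxyphenoxy swap on the shorter chain: working notes

This account rests on a few compounds, and the source may have more. Where it says the series, first, only, none or still open, it means among the compounds named here.

Values in a functional assay on ileum (Cavia porcellus) for antagonist activity, with a stated time of 30 s; a higher number here means a weaker inhibitor, a lower number a stronger inhibitor:
- compound 1 `O=C(O)c1cc(=O)c2ccc(OCCCCCCCOc3ccccc3)cc2o1`: 1.8 ug/mL
- compound 2 `O=C(O)c1cc(=O)c2ccc(OCCCCCCCCCOc3ccccc3)cc2o1`: 1.8 ug/mL

Compound 1 stands level with compound 2 in this assay, so neither can be ranked above the other. The next structure is compound 3 `O=C(O)c1cc(=O)c2ccc(OCCCCCOc3cccc(O)c3)cc2o1`, and the change is 3-hydroxyphenoxy in place of 2-phenoxyethyl on a saturated chain carbon, five bonds along the chain from an oxygen on an aromatic ring. In words, this puts 3-hydroxyphenoxy in place of 2-phenoxyethyl on a saturated chain carbon, five bonds along the chain from an oxygen on an aromatic ring.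

Going by the values given here, only one measured step bears on this: no change at the digits printed from compound 1 to compound 2 (within the scatter). That step involved no hydroxy-bearing group, so the data do not cover the entering 3-hydroxyphenoxy, and the range must stay wide. No step beyond the scatter is expected in this assay, and no direction can be assigned with confidence. The expected step is a 1.4-fold higher number from compound 1 to compound 3 (0.14 log units; within the scatter). The estimate for compound 3 is 2.5 ug/mL, with an expected range of 0.6 ug/mL to 10 ug/mL.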

Compound 3, half-maximal inhibitory concentration: 1.5 ug/mL
The estimate for compound 3 lay 1.7-fold (0.22 log units) above the measured number; measured number inside the range.
By their numbers in this assay, from the lowest: compounds 3, 1 and 2 (each within the scatter of the next).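

In this assay the change to 3-hydroxyphenoxy in place of 2-phenoxyethyl on a saturated chain carbon, five bonds along the chain from an oxygen on an aromatic ring, gives a 1.2-fold lower number from compound 1 to compound 3 (0.08 log units; within the scatter) and so stays inside the usual spread. The earlier pair carried no hydroxy-bearing group; this step shows that a group with a hydrogen-bond donor can enter at this place without a step beyond the scatter. No supporting data explain this level read-out.

Going by these compounds alone, the single step does not separate the entering hydroxy from the change in the group as a whole. Open questions are whether 3-hydroxyphenoxy on a longer chain gives the same read-out, and whether an amine or a carboxylic acid in place of the hydroxy holds it too.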